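Trading a Methylsulfonyl Group for a Methylsulfanyl Group

This account rests on a few compounds, and the source may have more. Where it says the series, first, only, none or still open, it means among the compounds named here.

Compound 3 `CS(=O)(=O)c1ccc(Cl)cc1NCC1=NCCN1` stands at the weak end of the numbers gathered so far. In a functional assay on CHO cells for agonist activity at Alpha-2C adrenergic receptor (Homo sapiens) (on this read-out higher numbers stand for an effect only at larger amounts of compound and lower numbers for an effect already at smaller amounts), compound 3 gives 794 nM, which sets it far apart from the other two: compound 1 `CSc1ccc(C)cc1NCC1=NCCN1` gives 8.91 nM and compound 2 `CSc1ccc(F)cc1NCC1=NCCN1` gives 5.62 nM in this assay. For the measured compounds named here, the only step measured between these compounds, a 1.6-fold lower number from compound 1 to compound 2 (0.20 log units; within the scatter), shows that exchanging methyl for fluoro hardly moves the number, so the wide gap to compound 3 cannot come from that kind of change.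

Compound 4 `CSc1ccc(Cl)cc1NCC1=NCCN1` is made from compound 3 by one change: methylsulfanyl in place of methylsulfonyl on an aromatic carbon. Going by the values given here, no measured step covers this particular exchange of the sulfur group. Among the compounds with values here, what the data do show is that the two methylsulfanyl compounds sit close together, while the one methylsulfonyl compound sits far from both. Compound 4 carries the methylsulfanyl group, and on that basis it is expected to land in the region of the two methylsulfanyl compounds, which would mean a 110-fold lower number from compound 3 to compound 4 (2.05 log units; beyond the scatter). The estimate for compound 4 in this assay is 7 nM, with a likely range from 2.5 nM to 30 nM.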

Compound 4, half-maximal effective concentration: 2.82 nM
Compound 4: the middle estimate sits 2.5-fold (0.39 log units) above what was measured; the range from low to high includes it.
By their numbers in this assay, from the lowest: compounds 4, 2 and 1 (each within the scatter of the next, the first and the last beyond it); then compound 3.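

With the chloro group held fixed, the exchange of methylsulfonyl for methylsulfanyl gives a 280-fold lower number from compound 3 to compound 4 (2.45 log units; beyond the scatter) in this assay, so the wide gap that earlier separated compound 3 from compounds that also differed in a second place now belongs to this single change on the aromatic carbon. The group para to the sulfur group matters far less on the same read-out: chloro in place of fluoro gives a 2.0-fold lower number from compound 2 to compound 4 (0.30 log units; within the scatter) and chloro in place of methyl gives a 3.2-fold lower number from compound 1 to compound 4 (0.50 log units; beyond the scatter), a real but small shift beside the sulfur exchange. Nothing available explains why the exchange of sulfur groups has so large an effect.

Compound 3 is the only methylsulfonyl compound shown, so it remains open whether the sulfur exchange would keep its size with fluoro or methyl in place of chloro. As far as these compounds go, it is also open how a methylsulfinyl group, a methoxy group, an amine or a longer chain such as ethylsulfanyl would behave on this same aromatic carbon, and whether any of them would keep the number as low as methylsulfanyl does.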